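Bicyclic Sulfonyl Substituents and Serotonin Receptor Binding

The source may report more compounds than this note shows. Statements on the series, on what has been measured and on what is new or still open speak of the compounds shown alone.

Three arylsulfonamides built on one shared core were compared in an assay on isolated protein for binding affinity to 5-hydroxytryptamine receptor 6 (Homo sapiens), tested at 10 uM; on this read-out higher numbers stand for more inhibition at the one concentration tested (going by the name of the read-out) and lower numbers for less inhibition. Compound 1 `CC(C)Cc1cc(CNS(=O)(=O)c2cccc3ccccc23)nn1-c1ccccc1` gives 77.7% in this assay. Compound 2 `CC(C)Cc1cc(CNS(=O)(=O)c2ccc(C(C)(C)C)cc2)nn1-c1ccccc1` gives 51.1%, and compound 3 `CC(C)Cc1cc(CNS(=O)(=O)c2ccccc2)nn1-c1ccccc1` gives 11.3%, the lowest of the three; the steps of a number 26.6 percentage points lower from compound 1 to compound 2 (beyond the scatter), a number 66.4 percentage points lower from compound 1 to compound 3 (beyond the scatter) and a number 39.8 percentage points lower from compound 2 to compound 3 (beyond the scatter) all lie beyond the scatter. Compound 4 `CC(C)Cc1cc(CNS(=O)(=O)c2ccc3ccccc3c2)nn1-c1ccccc1` differs from compound 3 by naphthalen-2-yl in place of phenyl on a sulfonyl sulfur. Going by the values given here, the closest measured step runs the other way: a number 66.4 percentage points lower from compound 1 to compound 3 (beyond the scatter) was large, and a number 39.8 percentage points lower from compound 2 to compound 3 (beyond the scatter) points the same way, although no measured step compares naphthalen-2-yl with naphthalen-1-yl. For compound 4 a large upward step is therefore expected, a number 48.7 percentage points higher from compound 3 to compound 4 (beyond the scatter). Compound 4 is estimated at 60%, within 30% to 85%.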

Compound 4, a percentage reported as inhibition, at one concentration (the size of the read-out at that concentration, not a potency): 67.8%
For compound 4 the middle estimate is 7.8 percentage points below the measured one, and the stated range covers the measured number.
By their numbers in this assay, from the lowest: compound 3; then compound 2; then compounds 4 and 1 (each within the scatter of the next).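

In this assay, the step of a number 56.5 percentage points higher from compound 3 to compound 4 (beyond the scatter) shows that a large rise on the sulfonyl sulfur is not confined to naphthalen-1-yl, since a number 9.9 percentage points lower from compound 1 to compound 4 (within the scatter) leaves the two naphthyl isomers apart by no more than the usual scatter. Naphthalen-2-yl also stands clear of the bulky monocyclic group, with a number 16.7 percentage points higher from compound 2 to compound 4 (beyond the scatter) showing that 4-(tert-butyl)phenyl does not match it. Nothing at hand explains these differences. Still open, on these data alone, is whether a dimethylamino group on the naphthalen-2-yl ring would keep this level of inhibition. As far as these compounds go, whether a quinoline in its place would do so is equally open.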